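The compounds below may be only part of what the source reports. "The series", "measured", "known", "first", "only" and "open" are said of these compounds alone.

For the measured compounds named here, compound 3 `O=C(/C(=C\c1ccc(Br)c(O)c1)S(=O)(=O)c1ccc(Br)cc1)c1ccc(Br)cc1` stands at the high end of the three numbers so far in a functional assay on DU-145 cells (Homo sapiens) for inhibition, read by trypan blue exclusion, with a stated time of 96 h; a lower number here means a stronger inhibitor of growth, a higher number a weaker inhibitor of growth: compound 3 gives 50000 nM, while compound 1 `O=C(/C(=C\c1csc([N+](=O)[O-])c1)S(=O)(=O)c1ccc(Br)cc1)c1ccc(Br)cc1` gives 1000 nM and compound 2 `O=C(/C(=C\c1ccc(F)cc1)S(=O)(=O)c1ccc(Br)cc1)c1ccc(Br)cc1` gives 4000 nM. The gaps are a 50-fold higher number from compound 1 to compound 3 (1.70 log units; beyond the scatter) and a 13-fold higher number from compound 2 to compound 3 (1.10 log units; beyond the scatter), both beyond the scatter, so compound 3 is the weakest inhibitor of growth among the three.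

Compound 4 `O=C(/C(=C\c1ccc(Br)c([N+](=O)[O-])c1)S(=O)(=O)c1ccc(Br)cc1)c1ccc(Br)cc1` differs from compound 3 by nitro in place of hydroxy on an aromatic carbon on an aromatic carbon ortho to a bromo group and meta to a large group.

Going by the values given here, no measured step exchanges hydroxy for nitro on the same ring. The nearest bearing is a 50-fold higher number from compound 1 to compound 3 (1.70 log units; beyond the scatter), where the nitro-bearing compound 1 sits far lower, and a 13-fold higher number from compound 2 to compound 3 (1.10 log units; beyond the scatter), where a ring without hydroxy also sits lower; neither isolates the present change, so only part of those steps is expected to carry over. A downward step of modest size, a 5.0-fold lower number from compound 3 to compound 4 (0.70 log units; beyond the scatter), is therefore expected in this assay. Compound 4 is estimated at 10000 nM, with a range of 2500 nM to 40000 nM.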

Compound 4, concentration for 50% growth inhibition: 10000 nM
Compound 4: the middle estimate sits on the measured number at the digits printed; measured number inside the range.
By their numbers in this assay, from the lowest: compound 1; then compound 2; then compound 4; then compound 3.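

In this assay, for the compounds shown here, nitro in place of hydroxy on the aromatic carbon ortho to a bromo group gives a 5.0-fold lower number from compound 3 to compound 4 (0.70 log units; beyond the scatter), the first step that alters this one position while the bromo group stays in place. Even so, the 4-bromo-3-nitrophenyl ring does not match the other two rings: in place of 4-fluorophenyl it gives a 2.5-fold higher number from compound 2 to compound 4 (0.40 log units; beyond the scatter), and in place of 5-nitrothiophen-3-yl it gives a 10-fold higher number from compound 1 to compound 4 (1.00 log units; beyond the scatter). A nitro group on the ring is therefore not enough by itself to reach the level of compound 1, as compound 4 carries one and remains the weaker of the two.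

Nothing at hand gives a reason for the step at this position. On these data alone, it remains open how an amine or a carboxylic acid on the same aromatic carbon would compare with compound 4, and whether the nitro step holds without the bromo group.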